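Phenyl for Dichlorophenyl: Expected Effect on Cell Growth

A few compounds are considered here, and "the series" means these few. Any claim that something is new, unique, unknown or untested is made for them only; others in the source may bear on it.

Three compounds have been measured in a functional assay on U-87MG ATCC cells for antiproliferative activity against U-87 MG (Homo sapiens), read by MTT assay, with a stated time of 48 h, tested at 10 uM; a lower number here means a stronger effect, a higher number a weaker effect of the compound at the concentration tested:

Compound 1, `Cc1nc(-c2ccc(Cl)cc2)sc1C(=O)CSc1nc(-c2ccccc2)c(C#N)c(=O)[nH]1`: 83.1%
Compound 2, `Cc1nc(-c2ccc(Cl)cc2)sc1C(=O)CSc1nc(-c2ccc(Cl)c(Cl)c2)c(C#N)c(=O)[nH]1`: 97.1%
Compound 3, `COc1ccc(-c2nc(C)c(C(=O)CSc3nc(-c4ccc(Cl)c(Cl)c4)c(C#N)c(=O)[nH]3)s2)cc1`: 88.6%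

Compound 2 and compound 1 differ in one place, (phenyl in place of 3,4-dichlorophenyl on an aromatic carbon); that change gave a number 14 percentage points lower from compound 2 to compound 1 (beyond the scatter). Compound 3 differs from compound 2 in its core, (methoxy in place of chloro on an aromatic carbon), and the step was a number 8.5 percentage points lower from compound 2 to compound 3 (within the scatter), so compound 3 and compound 2 cannot be ordered.

Compound 4, `COc1ccc(-c2nc(C)c(C(=O)CSc3nc(-c4ccccc4)c(C#N)c(=O)[nH]3)s2)cc1`, is not yet measured. Within the data shown here, it differs from compound 3 in phenyl in place of 3,4-dichlorophenyl on an aromatic carbon, the same change at the same place as the one already seen between compound 2 and compound 1. Compound 4 is expected to show a number 13.6 percentage points lower from compound 3 to compound 4 (beyond the scatter) because the earlier instance gave a number 14 percentage points lower from compound 2 to compound 1 (beyond the scatter), though this rests on one pair only. Compound 4 is estimated at 75%, with a likely range from 62% to 88%.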

Compound 4, a percentage reported as activity, at one concentration (the size of the read-out at that concentration, not a potency): 90.9%
Estimate against measurement, compound 4: 15.9 percentage points below; measured number above the stated range.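

In this assay, phenyl in place of 3,4-dichlorophenyl did not carry over from one core to the other, giving a number 2.3 percentage points higher from compound 3 to compound 4 (within the scatter), and the two instances differ: the same change on two cores in this assay, a number 14 percentage points lower (beyond the scatter) from compound 2 to compound 1 and a number 2.3 percentage points higher (within the scatter) from compound 3 to compound 4, 16.3 percentage points apart, beyond the scatter of two such steps. Methoxy in place of chloro gave a number 7.8 percentage points higher from compound 1 to compound 4 (within the scatter), and its two instances differ as well: the same change on two cores in this assay, a number 8.5 percentage points lower (within the scatter) from compound 2 to compound 3 and a number 7.8 percentage points higher (within the scatter) from compound 1 to compound 4, 16.3 percentage points apart, beyond the scatter of two such steps. These four compounds show that neither change can be assumed to transfer unchanged between these cores, but they do not show why, nor how either change would behave on a further core.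

The compounds shown leave open how an amine or a carboxylic acid would read in place of the phenyl. They also leave open what a fluoro group in place of the chloro on the other aryl ring would give.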